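This account rests on a few compounds, and the source may have more. Where it says the series, first, only, none or still open, it means among the compounds named here.

Measured compounds:
compound 1, `CCN(Cc1ccccc1)C(=O)Nc1c(-c2ccccc2)c2cc(C)c(C)cc2c(=O)n1C` — 66 nM in an assay on IM-9 cells for binding affinity to Substance-P receptor (Homo sapiens); a higher number here means a weaker inhibitor, a lower number a stronger inhibitor
compound 2, `Cc1cc2c(-c3ccccc3)c(C(=O)N(C)Cc3cc(C(F)(F)F)cc(C(F)(F)F)c3)n(C)c(=O)c2cc1C` — 8.4 nM in this assay

Compound 1 stands as the higher of the two numbers in this assay; compound 2 gives the lower value, and the gap between them lies beyond the usual scatter. Within the data shown here, no step between two measured compounds that differ in a single place is available, so nothing in the measured data isolates the effect of any one structural change on its own.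

Compound 3, `Cc1cccc(NC(=O)Nc2c(-c3ccccc3)c3cc(C)c(C)cc3c(=O)n2C)c1`, has not yet been measured. It differs from compound 1 in one place: (3-methylphenyl)amino in place of benzyl(ethyl)amino on a carbonyl carbon. The shared core of compound 1 and compound 3 is otherwise unchanged, and compound 2 carries a different linking group, so its value gives no direct guide for this change.

Among the measured compounds shown here, with no comparable step in hand, the expectation for compound 3 rests on compound 1 alone, and a modest shift toward a weaker value is expected, a 1.8-fold higher number from compound 1 to compound 3 (0.26 log units; within the scatter), with wide uncertainty. Compound 3 is therefore estimated at 120 nM in this assay, within a range of 30 nM to 500 nM.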

Compound 3, half-maximal inhibitory concentration: 840 nM
Compound 3: the middle estimate sits 7.0-fold (0.85 log units) below what was measured; the measured number lies above the stated range.
By their numbers in this assay, from the lowest: compound 2; then compound 1; then compound 3.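

Notes on the carbonyl carbon whose other neighbour is an amide-type nitrogen: in this assay, (3-methylphenyl)amino in place of benzyl(ethyl)amino gives a 13-fold higher number from compound 1 to compound 3 (1.10 log units; beyond the scatter) and a weaker inhibitor. Among these compounds, this is the first single-place comparison, and it shows that the group on this carbonyl carbon can move the value well beyond the scatter even though the rest of the compound is unchanged. The change alters several features at once, with 10 heavy atoms leaving and 8 entering, one carbon-only aromatic ring on each side and 1 hydrogen-bond donor entering, and no measurement available here bears on which of these matters.

Among the compounds shown here, the single step leaves open whether the shift follows the gained amide hydrogen, the absent ethyl or the aromatic ring attached directly to the nitrogen rather than through a carbon. Benzylamino would keep the benzyl group while carrying the amide hydrogen, and ethyl(3-methylphenyl)amino would keep the 3-methylphenyl group without that hydrogen, so each would help to separate these features.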